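The compounds below may be only part of what the source reports. "The series", "measured", "known", "first", "only" and "open" are said of these compounds alone.

Measured so far:
compound 1 `COc1ccccc1NC(=S)N/N=C/c1ccc2ccccc2n1` — > 100000 nM
compound 2 `CN(C)C(=S)N/N=C/c1cnc2ccccc2n1` — 170 nM

In a functional assay on SGC-7901 cells (Homo sapiens) for antiproliferative activity, read by sulforhodamine B assay, with a stated time of 72 h (a higher number here means a weaker inhibitor, a lower number a stronger inhibitor), compound 1 gives only a limit, > 100000 nM, and no number. It therefore sits at the limit of > 100000 nM in this assay, at which 1 of the 2 values shown sits. Compound 2 gives 170 nM in this assay. Within the data shown here, no step between these two is worked out here, as they differ in more than one place.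

Compound 3 `Fc1cccc(NC(=S)N/N=C/c2ccc3ccccc3n2)c1` differs from compound 1 by 3-fluorophenyl in place of 2-methoxyphenyl on an amide-type nitrogen. Among the measured compounds shown here, with compound 1 at a limit, no measured step guides this change; a step in this assay of no size beyond the scatter is expected, in either direction. Compound 3 is thus estimated at 100000 nM (range 20000 nM to 300000 nM), an expected step of a number no higher from compound 1 to compound 3 (the limit leaves the size open).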

Compound 3, half-maximal inhibitory concentration: 79900 nM
The estimate for compound 3 lay 1.3-fold (0.10 log units) above the measured number; low and high end bracket the measured number.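

In this assay, 3-fluorophenyl in place of 2-methoxyphenyl on an amide-type nitrogen gives an at least 1.2-fold lower number from compound 1 to compound 3 (0.09 log units; that floor lies within the scatter). Compound 1 is a limit and not a number: the limit of > 100000 nM in this assay, at which 1 of the 3 values shown sits. Compound 3, at 79900 nM, gives this position its first measured number on the core of compound 1, a point from which further changes can be read.

The step swaps two different phenyl groups at once, so the part played by the fluorine or the methoxy cannot be separated. Open too, as far as these compounds go, is how unsubstituted phenyl, or a phenyl carrying an amine or a carboxylic acid, behaves on this nitrogen.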